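Propoxy to pentyl in the tert-butyl amide series

The source may hold more compounds than are shown below. What is called first, only, known or untested is meant among the compounds shown, and "the series" means these compounds.

Compound 1 `CCCCSc1nc(C(C)(C)C)ccc1CNC(=O)C(C)c1ccc(NS(C)(=O)=O)c(F)c1`: 3.2 nM
Compound 2 `CC(C(=O)NCc1ccc(C(C)(C)C)nc1SC1CCCC1)c1ccc(NS(C)(=O)=O)c(F)c1`: 2.5 nM
Compound 3 `CCCOc1cc(C(C)(C)C)ccc1CNC(=O)C(C)c1ccc(NS(C)(=O)=O)c(F)c1`: 4.4 nM

In an assay on cells for antagonist activity at transient receptor potential cation channel subfamily V member 1 (Homo sapiens), read by FLIPR and calcium flux, with a stated time of 6 min (on this read-out lower numbers stand for stronger inhibition and higher numbers for weaker inhibition), compound 3 gives 4.4 nM, the highest of the three numbers, though its gaps to compound 1 and to compound 2 both lie within the usual scatter. Going by the values given here, the single measured step, a 1.3-fold lower number from compound 1 to compound 2 (0.11 log units; within the scatter), exchanges a group on sulfur and also stays within the scatter. Compound 4 `CCCCCc1cc(C(C)(C)C)ccc1CNC(=O)C(C)c1ccc(NS(C)(=O)=O)c(F)c1` differs from compound 3 by pentyl in place of propoxy on an aromatic carbon. Among the compounds with values here, no measured step swaps an oxygen-linked chain for an all-carbon chain on this ring, so the one step in hand bears on it only as a sign that chain changes of this kind have stayed small. The expected step is a 1.1-fold higher number from compound 3 to compound 4 (0.06 log units; within the scatter), not beyond the scatter. Compound 4 is estimated at 5 nM, with a range of 2 nM to 13 nM.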

Compound 4, inhibition constant: 2.8 nM
Estimate against measurement, compound 4: 1.8-fold (0.25 log units) above; the range from low to high includes it.
By their numbers in this assay, from the lowest: compounds 2, 4, 1 and 3 (each within the scatter of the next).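

In this assay, the all-carbon pentyl in place of propoxy on an aromatic carbon, ortho to a large group, gives a 1.6-fold lower number from compound 3 to compound 4 (0.20 log units; within the scatter). At this position, therefore, the oxygen and the hydrogen-bond acceptor of propoxy can be lost without a change beyond the scatter. No measurement shown gives a reason for this result.

Open, as far as these compounds go, is whether an amine, a carboxylic acid or a chain longer than pentyl on this aromatic carbon would stay in the same range. Also open, from the compounds shown here alone, is whether a cyclopentyl group there would do so.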